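Moving the ethyl group around the phenyl ring

The source may report more compounds than this note shows. Statements on the series, on what has been measured and on what is new or still open speak of the compounds shown alone.

In an assay on microsomes from liver for inhibition of acyl-CoA desaturase 1 (Rattus norvegicus) (on this read-out lower numbers stand for stronger inhibition and higher numbers for weaker inhibition), compound 2 `CCc1ccccc1OC1CCN(c2ccc(-n3ccnc3)nn2)CC1` gives 4 nM, which sits level with compound 1 `FC(F)(F)c1ccccc1OC1CCN(c2ccc(-n3ccnc3)nn2)CC1`, where compound 1 gives 4 nM; these two share the highest number of the three shown. Compound 3 `OCc1nnc(-c2ccc(N3CCC(Oc4ccccc4C(F)(F)F)CC3)nn2)o1` gives 2.9 nM, the lowest of the three, though the step of a 1.4-fold lower number from compound 1 to compound 3 (0.14 log units; within the scatter) stays within the scatter. The step of no change at the digits printed from compound 1 to compound 2 (within the scatter), ethyl in place of trifluoromethyl on an aromatic carbon, shows that the group at this position can be exchanged without any shift in this assay.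

Compound 4 `CCc1cccc(OC2CCN(c3ccc(-n4ccnc4)nn3)CC2)c1` has the same atoms as compound 2, joined differently: 3-ethylphenyl in place of 2-ethylphenyl on an oxygen on a saturated carbon. No measured step moves a group around this ring, so the two steps shown bear on it only loosely. Both of them, no change at the digits printed from compound 1 to compound 2 (within the scatter) and a 1.4-fold lower number from compound 1 to compound 3 (0.14 log units; within the scatter), fall within the scatter, which suggests that this part of the structure tolerates change. On that basis, compound 4 is expected to show a step of a 1.5-fold higher number from compound 2 to compound 4 (0.18 log units; within the scatter) that is no larger than the scatter, with a modest drift towards a higher number remaining possible. Compound 4 is therefore estimated at 6 nM, with a range from 2 nM to 20 nM.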

Compound 4, half-maximal inhibitory concentration: 38 nM
The estimate for compound 4 lay 6.3-fold (0.80 log units) below the measured number; measured number above the stated range.
By their numbers in this assay, from the lowest: compounds 3, 1 and 2 (each within the scatter of the next); then compound 4.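

In this assay, 3-ethylphenyl in place of 2-ethylphenyl on an oxygen on a saturated carbon gives a 9.5-fold higher number from compound 2 to compound 4 (0.98 log units; beyond the scatter), so where the ethyl group sits on this ring matters, even though the two compounds have the same atoms. The earlier step of no change at the digits printed from compound 1 to compound 2 (within the scatter) had exchanged one group for another without moving it around the ring, and the tolerance it showed therefore does not extend to this move. The data shown offer no explanation for the rise in the number.

As far as these compounds go, only this one move of one group around the ring can be read, so it remains open whether trifluoromethyl would respond to the same move as ethyl does, and whether a longer chain such as propyl, a methoxy group or an amine would follow the same trend. From the compounds shown here alone, it is also open whether the effect of the move depends on the rest of the molecule, for instance whether it would be as large with 5-(hydroxymethyl)-1,3,4-oxadiazol-2-yl in place of 1H-imidazol-1-yl on the shared core.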